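Acetoxy to carbamoyloxy: working notes on the series

The source may hold more compounds than are shown below. What is called first, only, known or untested is meant among the compounds shown, and "the series" means these compounds.

In a functional assay on V79-379A cells (Cricetulus griseus) for cytotoxicity, read by MTT assay, in the presence of a further agent that is not named here (a lower number here means a stronger inhibitor, a higher number a weaker inhibitor), the values so far are:
- compound 1 `COC1=CC(=O)c2c(c(CCl)cn2C)C1=O` gives 304000 nM
- compound 2 `COC1=CC(=O)c2c(c(COC(C)=O)c(C)n2C)C1=O` gives 27000 nM

Compound 2 at 27000 nM holds the lower of the two numbers, and compound 1 at 304000 nM lies above it, beyond the scatter.

Compound 3 `COC1=CC(=O)c2c(c(COC(N)=O)c(C)n2C)C1=O` is still to be measured in this assay on the same terms. It differs from compound 2 by amino in place of methyl on a carbonyl carbon so that acetoxymethyl becomes (carbamoyloxy)methyl. Among the measured compounds shown here, no measured pair shows this change, and the expectation rests on the structural change alone: a small move toward a higher number, within the scatter. The expected step is a 1.5-fold higher number from compound 2 to compound 3 (0.17 log units; within the scatter) as an estimate. For compound 3 the estimate is 40000 nM with an expected range from 12000 nM to 130000 nM as its upper end.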

Compound 3, half-maximal inhibitory concentration: 25000 nM
Compound 3: the middle estimate sits 1.6-fold (0.20 log units) above what was measured; measured number inside the range.
By their numbers in this assay, from the lowest: compounds 3 and 2 (each within the scatter of the next); then compound 1.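

In this assay, among the compounds shown here, the change from acetoxy to carbamoyloxy gives a 1.1-fold lower number from compound 2 to compound 3 (0.03 log units; within the scatter) and is the first single-place comparison. At this position, amino and methyl on a carbonyl carbon therefore cannot be told apart, even though a hydrogen-bond donor enters with the amino. No evidence bearing on this result is at hand.

Compound 1 differs from compound 2 in more than one place, and the gap between their values is tied to no single group. Still open, going by these compounds, is how a methylamino or dimethylamino group in place of this amino would read on the shared core, and whether a hydroxymethyl group in place of (carbamoyloxy)methyl would keep the level of compound 2 and compound 3.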